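The source may report more compounds than this note shows. Statements on the series, on what has been measured and on what is new or still open speak of the compounds shown alone.

Measured in a functional assay on RPMI-8226 cells (Homo sapiens) for cytotoxicity, read by CCK-8 assay, with a stated time of 72 h (on this read-out higher numbers stand for weaker inhibition and lower numbers for stronger inhibition), so far
- compound 1 `O=C(CCCCCCC(=O)Nc1ccc2ccnc(Nc3ccc(Br)cc3F)c2c1)NO` gives 460 nM
- compound 2 `Cc1ccc(Nc2nccc3ccc(NC(=O)CCCCCCC(=O)NO)cc23)c(Br)c1` gives 470 nM

In this assay, within the data shown here, compound 2 gives 470 nM, level with compound 1, the only other measured compound. Compound 3 `O=C(CCCCCCC(=O)Nc1ccc2ccnc(Nc3ccccc3F)c2c1)NO` has not yet been measured. It differs from compound 2 as follows: 2-fluorophenyl in place of 2-bromo-4-methylphenyl on a nitrogen on an aromatic ring. In short, 2-fluorophenyl stands in place of 2-bromo-4-methylphenyl on a nitrogen on an aromatic ring.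

Among the measured compounds shown here, only one measured step concerns this place: a 1.0-fold higher number from compound 1 to compound 2 (0.01 log units; within the scatter). That swap of one substituted phenyl for another changed nothing measurable. For the measured compounds named here, it offers a weak guide, though, since both measured compounds carry bromine and compound 3 does not, and no measured compound shows what losing it does. No clear direction can be expected, so the expected step is a 1.1-fold higher number from compound 2 to compound 3 (0.03 log units; within the scatter), nothing beyond the scatter. For compound 3 the estimated value is 500 nM, with an expected range from 200 nM to 1300 nM.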

Compound 3, half-maximal inhibitory concentration: 940 nM
Estimate against measurement, compound 3: 1.9-fold (0.27 log units) below, within the range that was stated.
By their numbers in this assay, from the lowest: compounds 1, 2 and 3 (each within the scatter of the next, the first and the last beyond it).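

In this assay, among these compounds, taking away the bromo group and leaving hydrogen on that aromatic carbon gives a 2.0-fold higher number from compound 1 to compound 3 (0.31 log units; beyond the scatter) and so marks the first step that clears the usual scatter, though only modestly. The larger swap of 2-bromo-4-methylphenyl for 2-fluorophenyl on the nitrogen gives a 2.0-fold higher number from compound 2 to compound 3 (0.30 log units; within the scatter) and so does not separate those two compounds, which means that this position has shown only a small response so far. No measurement available here explains the difference.

Going by these compounds, it remains open whether chloro, methyl or methoxy on that aromatic carbon would match bromo. A plain phenyl group on the nitrogen would also be needed to show what the fluoro group contributes.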